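Fluoro for Methoxy on Two Related Cores: Cytotoxicity

The source may hold more compounds than are shown below. What is called first, only, known or untested is meant among the compounds shown, and "the series" means these compounds.

Compound 1 `CCOC(=O)c1c(-c2ccc(OC)cc2)oc2ccc(OCCCCCCN3C(=O)/C(=N\OC)c4cc(F)ccc43)cc12`: 16 ug/mL
Compound 2 `CCOC(=O)c1c(-c2ccc(OC)cc2)oc2ccc(OCCCCCCN3C(=O)C(=O)c4cc(F)ccc43)cc12`: 1020 ug/mL
Compound 3 `CCOC(=O)c1c(-c2ccc(F)cc2)oc2ccc(OCCCCCCN3C(=O)/C(=N\OC)c4cc(F)ccc43)cc12`: 16 ug/mL

These three compounds were measured in an ADME assay on Vero cells (Chlorocebus sabaeus) for cytotoxicity, read by MTT assay, with a stated time of 72 h; on this read-out higher numbers stand for lower toxicity in this test and lower numbers for higher toxicity in this test. In this assay compound 1 gives 16 ug/mL, compound 3 gives 16 ug/mL and compound 2 gives 1020 ug/mL. Compound 3 differs from compound 1 by fluoro in place of methoxy on an aromatic carbon, and the step is no change at the digits printed from compound 1 to compound 3 (within the scatter). Compound 2 shares the core of compound 1 only in part; the difference between the two cores is not broken down here, but compound 2 stands far from both others in this assay, beyond the scatter.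

Compound 4 `CCOC(=O)c1c(-c2ccc(F)cc2)oc2ccc(OCCCCCCN3C(=O)C(=O)c4cc(F)ccc43)cc12` is not yet measured. It differs from compound 2 by fluoro in place of methoxy on an aromatic carbon, the same change as from compound 1 to compound 3, made at the same place. Because the step from compound 1 to compound 3 was no change at the digits printed from compound 1 to compound 3 (within the scatter), the step from compound 2 to compound 4 is expected to be about a 1.1-fold lower number from compound 2 to compound 4 (0.03 log units; within the scatter). Compound 4 is therefore estimated to give about 950 ug/mL in this assay, expected between 350 ug/mL and 2500 ug/mL.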

Compound 4, half-maximal cytotoxic concentration: 512 ug/mL
The estimate for compound 4 lay 1.9-fold (0.27 log units) above the measured number, within the range that was stated.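

In this assay, fluoro in place of methoxy gives a 2.0-fold lower number from compound 2 to compound 4 (0.30 log units; within the scatter), and set beside the step on the other core, the two steps agree: the same change on two cores in this assay, no change at the digits printed (within the scatter) from compound 1 to compound 3 and a 2.0-fold lower number (0.30 log units; within the scatter) from compound 2 to compound 4, 2.0-fold (0.30 log units) apart, within the scatter of two such steps. In this series, then, the change carried from the core of compound 1 to the core of compound 2 without a difference that rises above the scatter. This rests on two pairs in a single assay, so it does not show that the change would behave the same way on any other core, and it gives no reason for the result.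

The compounds shown leave open whether chloro, an amine or a carboxylic acid at that place would behave like fluoro. They also leave open what a longer chain would do on either core.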